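The source may hold more compounds than are shown below. What is called first, only, known or untested is meant among the compounds shown, and "the series" means these compounds.

Compound 1 `CC(=O)C1=C(C)NC(=O)NC1c1ccsc1` in an assay on membranes from HEK293 cells for displacement of a labelled ligand from adenosine receptor A2b (Homo sapiens), read by scintillation counting, with a stated time of 30 min, tested at 1 uM (a higher number here means more inhibition at the concentration tested (going by the name of the read-out), a lower number less inhibition), gives 24%. For the measured compounds named here, compound 2 `CCN(CC)C(=O)C1=C(C)NC(=O)NC1c1ccsc1` gives 11% in this assay, the lowest of the two numbers so far; the one measured step, a number 13 percentage points lower from compound 1 to compound 2 (beyond the scatter), is diethylamino in place of methyl on a carbonyl carbon. Compound 3 `CC1=C(C(=O)SC(C)C)C(c2ccsc2)NC(=O)N1` differs from compound 2 by isopropylsulfanyl in place of diethylamino on a carbonyl carbon. Going by the values given here, that change is again on a carbonyl carbon, so the measured step is the only bearing on it, yet no pair shows isopropylsulfanyl, so there is little to go on. Compound 3 is expected to move back toward compound 1, an estimated a number 7 percentage points higher from compound 2 to compound 3 (within the scatter) in this assay. Compound 3 is therefore estimated at 18%, within 5% to 35%.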

Compound 3, a percentage reported as inhibition, at one concentration (the size of the read-out at that concentration, not a potency): 14%
Compound 3: middle estimate off by 4 percentage points, on the high side; the range from low to high includes it.
By their numbers in this assay, from the lowest: compounds 2, 3 and 1 (each within the scatter of the next, the first and the last beyond it).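

In this assay, isopropylsulfanyl in place of diethylamino on a carbonyl carbon gives a number 3 percentage points higher from compound 2 to compound 3 (within the scatter), so these two groups are not told apart at this place. Isopropylsulfanyl in place of methyl gives a number 10 percentage points lower from compound 1 to compound 3 (within the scatter), which leaves compound 3 within the scatter of both neighbours, while only the step of a number 13 percentage points lower from compound 1 to compound 2 (beyond the scatter) lies beyond it. No measurement shown here offers an explanation for these steps.

From the compounds shown here alone, whether a carboxylic acid or a longer alkyl chain on this carbonyl carbon would stand clearly apart from these values remains open. Potency also remains open, as these readings are from a single concentration.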